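The source may report more compounds than this note shows. Statements on the series, on what has been measured and on what is new or still open speak of the compounds shown alone.

In a functional assay on A549 cells (Homo sapiens) for inhibition, read by CCK-8 assay, with a stated time of 72 h, tested at 2 uM (on this read-out lower numbers stand for less inhibition of growth and higher numbers for more inhibition of growth at the one concentration tested), compound 1 `Nc1ccccc1NC(=O)/C=C/c1ccc(CSc2cccc(F)c2)cc1` gives 50.7%. Compound 2 `CCc1ccc(SCc2ccc(C(=O)Nc3ccccc3N)cc2)cc1` gives 53.6%, within the scatter of compound 1, while compound 3 `Cc1ccc(SCc2ccc(C(=O)Nc3ccccc3N)cc2)cc1` gives 40.5%, a lower number beyond the scatter. Compound 1 therefore stands level with compound 2, and both stand above compound 3.

Next in line is compound 4 `Nc1ccccc1NC(=O)/C=C/c1ccc(CSCCc2ccccc2)cc1`. The change is phenethyl in place of 3-fluorophenyl on a sulfur. Going by the values given here, the only measured step, a number 13.1 percentage points lower from compound 2 to compound 3 (beyond the scatter), is modest and beyond the scatter. It bears only indirectly, since it involves a much smaller change on a different core. Among the compounds with values here, no measured compound carries phenethyl, and no measured step replaces 3-fluorophenyl, so the direction is poorly defined. A small drop is expected in this assay, probably not beyond the scatter. The expected step is a number 5.7 percentage points lower from compound 1 to compound 4 (within the scatter). Compound 4 is estimated at 45%, with an expected range of 30% to 60%.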

Compound 4, percent growth inhibition at one concentration: 45.7%
Estimate against measurement, compound 4: 0.7 percentage points below; low and high end bracket the measured number.
By their numbers in this assay, from the lowest: compounds 3, 4, 1 and 2 (each within the scatter of the next, the first and the last beyond it).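

In this assay, the exchange on the sulfur reads a number 5 percentage points lower from compound 1 to compound 4 (within the scatter), so compound 1 and compound 4 cannot be told apart on this read-out. The earlier compounds shown here showed only a step at the far end of an alkyl-substituted aryl group, whereas this position also tolerates a complete exchange of 3-fluorophenyl for phenethyl, with the aromatic ring kept, the fluorine gone and a chain added, without a step beyond the scatter. No measurement at hand explains why the two groups read alike.

As far as these compounds go, the fluorine and the chain change together here, so their separate contributions remain open, and a plain phenyl group on the sulfur would separate them. Also open, from the compounds shown here alone, is whether the number holds with an amine, a carboxylic acid or a longer chain at this position.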